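This account rests on a few compounds, and the source may have more. Where it says the series, first, only, none or still open, it means among the compounds named here.

In a functional assay on MCF7 cells (Homo sapiens) for antiproliferative activity (a higher number here means a weaker inhibitor, a lower number a stronger inhibitor), the measured compounds stand as follows:
- compound 1 `CCNCCCOc1ccc2cc(NC(=O)c3ccc(O)c(CC=C(C)C)c3)c(=O)oc2c1C` gives 980 nM
- compound 2 `CC(C)=CCc1cc(C(=O)Nc2cc3ccc(OCCCNC(C)(C)C)c(C)c3oc2=O)ccc1O` gives 950 nM

Compound 2 cannot be separated from compound 1 on these numbers. Among the measured compounds shown here, the one measured step is a 1.0-fold lower number from compound 1 to compound 2 (0.01 log units; within the scatter) and it is tert-butyl in place of ethyl on an amine nitrogen.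

Compound 3 `CC(C)=CCc1cc(C(=O)Nc2cc3ccc(OCCCNCC(=O)O)c(C)c3oc2=O)ccc1O` is unmeasured. It differs from compound 2 by carboxymethyl in place of tert-butyl on an amine nitrogen. For the measured compounds named here, the step to compound 2 is the only one that bears on this change, and it bears only loosely: no measured compound carries carboxymethyl, so the data do not fix the size of the step in this assay and any estimate stays wide. A move to a higher number, beyond the scatter, is expected all the same. The expected step is a 3.2-fold higher number from compound 2 to compound 3 (0.50 log units; beyond the scatter) on this estimate. For compound 3 the estimated value is 3000 nM with an expected range of 800 nM to 12000 nM for the measurement.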

Compound 3, half-maximal inhibitory concentration: 18100 nM
The estimate for compound 3 lay 6.0-fold (0.78 log units) below the measured number; the whole stated range lies below it.
By their numbers in this assay, from the lowest: compounds 2 and 1 (each within the scatter of the next); then compound 3.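

Working notes on the amine nitrogen: in this assay, ethyl and tert-butyl on this nitrogen could not be told apart, so the earlier compounds showed tolerance only among these two alkyl groups. Carboxymethyl breaks that picture (a 19-fold higher number from compound 2 to compound 3 (1.28 log units; beyond the scatter)), and the same large move appears from the ethyl side, where carboxy stands in place of methyl on the saturated chain carbon bound to the amine nitrogen (an 18-fold higher number from compound 1 to compound 3 (1.27 log units; beyond the scatter)). Nothing available explains why this substituent gives the higher number.

Still open, from the compounds shown here alone, is whether the free carboxylic acid is what matters, or whether its methyl ester or primary amide on the same nitrogen would give a similar number. Also open, going by these compounds, is how a longer chain between the amine nitrogen and the carboxylic acid, or a hydroxyethyl group in its place, would read.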